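This account rests on a few compounds, and the source may have more. Where it says the series, first, only, none or still open, it means among the compounds named here.

Three compounds of the series share one core and carry a number in an ADME assay on microsomes from liver (Mus musculus, strain NMRI) for metabolic stability, tested at 2.5 uM; on this read-out lower numbers stand for slow clearance and higher numbers for fast clearance. Compound 1 `Fc1cc(Cl)ccc1-c1ccc(Cn2nnc3c(F)cccc32)cn1` gives 2.2 mL/min/g. Compound 2 `Fc1ccc2nnn(Cc3ccc(-c4ccc(Cl)cc4F)nc3)c2c1` gives 2.2 mL/min/g in this assay. Compound 3 `N#Cc1cccc2c1nnn2Cc1ccc(-c2ccc(Cl)cc2F)nc1` gives 1.6 mL/min/g in this assay. Compound 3 holds the lowest of the three numbers, yet its gaps to compound 1 and to compound 2 both lie within the scatter, so no order among the three can be read from these data. Going by the values given here, the only single-point step on record is a 1.4-fold lower number from compound 1 to compound 3 (0.14 log units; within the scatter).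

Compound 4 `Fc1cc(Cl)ccc1-c1ccc(Cn2nnc3c(Br)cccc32)cn1` has not been measured in this assay. It differs from compound 3 in one place: bromo in place of cyano on an aromatic carbon. Among the compounds with values here, no measured step exchanges a cyano for a bromo; the only comparison that involves the cyano group at all is the step from compound 1 to compound 3, and that step stayed within the scatter. With nothing on record pointing in either direction, the expectation for compound 4 is a number close to that of compound 3, with no step beyond the scatter, expressed as a 1.3-fold higher number from compound 3 to compound 4 (0.10 log units; within the scatter). Compound 4 is accordingly estimated at 2 mL/min/g, with a range from 1 mL/min/g to 4 mL/min/g.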

Compound 4, intrinsic clearance in a liver preparation (reported as CLH), per the amount of preparation that the assay uses: 3.8 mL/min/g
Compound 4: the middle estimate sits 1.9-fold (0.28 log units) below what was measured, within the range that was stated.
By their numbers in this assay, from the lowest: compounds 3, 1, 2 and 4 (each within the scatter of the next, the first and the last beyond it).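

At this place on the six-membered aromatic ring of carbon only, the substituent can now be seen to matter in this assay: the exchange of cyano for bromo gives the only step shown beyond the scatter, and it is modest (a 2.4-fold higher number from compound 3 to compound 4 (0.38 log units; beyond the scatter)). The exchange of fluoro for bromo at the same place stays within the scatter (a 1.7-fold higher number from compound 1 to compound 4 (0.24 log units; within the scatter)), as does the exchange of fluoro for cyano (a 1.4-fold lower number from compound 1 to compound 3 (0.14 log units; within the scatter)), so compound 1 cannot be separated from either compound 3 or compound 4. The three groups therefore form no full order here: only cyano and bromo can be told apart, and that distinction rests on a single pair of compounds.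

On these data alone, compound 2 carries fluoro at another place on the same ring, so whether cyano and bromo would differ to a similar extent there remains open. As far as these compounds go, how a methoxy group, an amine or a carboxylic acid at the place shared by compound 1, compound 3 and compound 4 would read in this assay also remains open.

Nothing at hand accounts for the difference between cyano and bromo.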